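Swapping the sulfonyl cap on the pyrrolidine of compound 1

The source may hold more compounds than are shown below. What is called first, only, known or untested is meant among the compounds shown, and "the series" means these compounds.

Compound 1 `CN1CCN(c2ccc(Nc3ncc4nc(Nc5ccccc5)n([C@H]5CCN(S(C)(=O)=O)C5)c4n3)cc2)CC1` sits second highest of three in a functional assay on HCC827 cells (Homo sapiens) for antiproliferative activity, read by MTT assay, with a stated time of 72 h (a higher number here means a weaker inhibitor, a lower number a stronger inhibitor), where compound 1 gives 17 nM. Compound 3 `CN1CCN(c2ccc(Nc3ncc4nc(Nc5ccc(F)cc5)n([C@H]5CCCN(S(=O)(=O)C6CC6)C5)c4n3)cc2)CC1` gives 8.6 nM, within the scatter of compound 1, while compound 2 `CN1CCN(c2ccc(Nc3ncc4nc(Nc5ccc(F)cc5)n(CCNS(=O)(=O)C5CC5)c4n3)cc2)CC1` gives 50 nM, beyond it. Among the measured compounds shown here, the only single-point step known is a 5.8-fold lower number from compound 2 to compound 3 (0.76 log units; beyond the scatter), which concerns the linker, not the sulfonyl group. Compound 4 `CN1CCN(c2ccc(Nc3ncc4nc(Nc5ccccc5)n([C@@H]5CCN(S(=O)(=O)C6CC6)C5)c4n3)cc2)CC1` differs from compound 1 by 1-(cyclopropylsulfonyl)pyrrolidin-3-yl in place of 1-(methylsulfonyl)pyrrolidin-3-yl on an aromatic nitrogen. For the measured compounds named here, no measured pair isolates a methylsulfonyl against a cyclopropylsulfonyl cap, so the expected step of a 1.4-fold lower number from compound 1 to compound 4 (0.15 log units; within the scatter) is estimated to stay within the scatter. Compound 4 is therefore expected to give about 12 nM, with a likely range from 4 nM to 40 nM.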

Compound 4, half-maximal inhibitory concentration: 0.88 nM
Compound 4: the middle estimate sits 14-fold (1.13 log units) above what was measured; measured number below the stated range.
By their numbers in this assay, from the lowest: compound 4; then compounds 3 and 1 (each within the scatter of the next); then compound 2.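

Moving to the cyclopropylsulfonyl cap gives a 19-fold lower number from compound 1 to compound 4 (1.29 log units; beyond the scatter) in this assay and shows that the group on this aromatic nitrogen can change the number by far more than the scatter, even with the pyrrolidine ring kept. The two structures are also drawn with opposite handedness at the ring carbon bonded to that nitrogen, so the step belongs to the whole group and not to the cyclopropyl ring alone. No available evidence explains the size of this step.

From the compounds shown here alone, it remains open whether the cyclopropylsulfonyl cap gives the same result with the handedness of compound 1. Going by these compounds, it is also open how an ethylsulfonyl or acetyl cap would compare.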